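The compounds below may be only part of what the source reports. "The series", "measured", "known", "first", "only" and "open" are said of these compounds alone.

Measured so far:
- compound 1 `O=C1C(=O)N(CCCn2cc(COc3cc(=O)oc4ccccc34)nn2)c2ccc(F)cc21` — 75%
- compound 2 `COc1ccc2c(c1)C(=O)C(=O)N2CCCCCn1cc(COc2cc(=O)oc3ccccc23)nn1` — 25%
- compound 3 `COc1ccc2c(c1)C(=O)C(=O)N2CCCCn1cc(COc2cc(=O)oc3ccccc23)nn1` — 48%

In a functional assay on HCT-116 cells (Homo sapiens) for inhibition, read by sulforhodamine B assay, with a stated time of 48 h, tested at 50 uM (a lower number here means less inhibition of growth, a higher number more inhibition of growth at the concentration tested), compound 2 gives 25%, the lowest of the three numbers. The nearest of the others is compound 3 with 48%, a gap beyond the scatter; compound 1 with 75% lies furthest away, also beyond the scatter. Going by the values given here, no pair of these three differs in one place only, so no single step can be isolated: compound 1 and compound 3 differ from compound 2 both in the linker and, in the case of compound 1, in the aromatic substituent as well.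

Compound 4 `O=C1C(=O)N(CCCCCn2cc(COc3cc(=O)oc4ccccc34)nn2)c2ccc(I)cc21` has not been measured. It differs from compound 2 in one place: iodo in place of methoxy on an aromatic carbon. Among the compounds with values here, the only halogen-bearing analogue, compound 1, shows the highest number, but its linker also differs, so the change cannot be assigned to the halogen alone. The expectation for this assay is a modest rise from compound 2 to compound 4, a number 15 percentage points higher from compound 2 to compound 4 (beyond the scatter), with a wide margin. Compound 4 is estimated at 40%, within a range of 15% to 65%.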

Compound 4, percent growth inhibition at one concentration: 36%
Beside the measured number, compound 4's estimate is 4 percentage points above it; low and high end bracket the measured number.
By their numbers in this assay, from the lowest: compound 2; then compound 4; then compound 3; then compound 1.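

In this assay, going by these compounds alone, the exchange of methoxy for iodo on the aromatic carbon gives a number 11 percentage points higher from compound 2 to compound 4 (beyond the scatter) with the rest of the structure unchanged, the first change that can be read in one place alone. The number at this position therefore responds to the group placed there, although this single pair shows only a modest step for one exchange and gives no trend across substituents. Nothing measured here bears on why the number moves.

Still open, going by these compounds, is whether chloro, an amine or a carboxylic acid at this position would move the number further than iodo does. Also open, on these data alone, is whether the step from methoxy to iodo would hold on a shorter chain.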